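This account rests on a few compounds, and the source may have more. Where it says the series, first, only, none or still open, it means among the compounds named here.

Compound 1 `Cc1cc(/C=C2\SC(=S)N(c3ccccc3)C2=O)c(C)n1-c1ccc(O)c(C(=O)O)c1` was tested in an ADME assay on MT2 cells (Homo sapiens) for cytotoxicity, read by XTT assay, with a stated time of 4 days; a lower number here means that less compound is tolerated, a higher number that more compound is tolerated. In this assay compound 1 gives only a limit, > 100000 nM, a reading that sits at the limit of > 100000 nM in this assay, at which 1 of the 3 values shown sits. Compound 4 `Cc1cc(/C=C2\SC(=S)N(Cc3ccccc3C(F)(F)F)C2=O)c(C)n1-c1ccc(O)c(C(=O)O)c1` differs from compound 1 in one place: 2-(trifluoromethyl)benzyl in place of phenyl on an amide-type nitrogen in a ring. Among the compounds with values here, two measured steps bear on this change. Compound 2 `COC(=O)c1ccc(CN2C(=O)/C(=C/c3cc(C)n(-c4ccc(O)c(C(=O)O)c4)c3C)SC2=S)cc1` gives 36900 nM in this assay, so that an at least 2.7-fold lower number from compound 1 to compound 2 (0.43 log units; beyond the scatter). Compound 3 `Cc1cc(/C=C2\SC(=S)N(Cc3cccc(C(F)(F)F)c3)C2=O)c(C)n1-c1ccc(O)c(C(=O)O)c1` gives 26300 nM in this assay, so that an at least 3.8-fold lower number from compound 1 to compound 3 (0.58 log units; beyond the scatter). A further step shows that a 1.4-fold lower number from compound 2 to compound 3 (0.15 log units; within the scatter). Both benzyl groups brought a lower number than the phenyl of compound 1, so a lower number is also expected here, namely an at least 3.3-fold lower number from compound 1 to compound 4 (0.52 log units; beyond the scatter). Compound 4 is therefore estimated at 30000 nM, with a likely range from 12000 nM to 80000 nM.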

Compound 4, half-maximal cytotoxic concentration: 28800 nM
Compound 4: middle estimate off by 1.0-fold (0.02 log units), on the high side; measured number inside the range.
By their numbers in this assay, from the lowest: compounds 3, 4 and 2 (each within the scatter of the next). At a limit, above all of these: compound 1.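

In this assay, 2-(trifluoromethyl)benzyl gives an at least 3.4-fold lower number from compound 1 to compound 4 (0.54 log units; beyond the scatter), so a third benzyl group joins the other two in reading lower than phenyl, though this step rests on a limit for compound 1. What is attached to the benzyl ring makes no difference that can be read here: the data show a 1.1-fold higher number from compound 3 to compound 4 (0.04 log units; within the scatter) and a 1.3-fold lower number from compound 2 to compound 4 (0.11 log units; within the scatter), both inside the usual scatter. Moving the trifluoromethyl group thus leaves the number unresolved from the earlier benzyl compounds. Still open, on these data alone, is whether the benzyl carbon alone accounts for the lower number, or whether the ring substituents also contribute. A plain benzyl, or a benzyl carrying an amine or a carboxylic acid, would test this.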